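Alpha-ketooxazole series: acetyl versus methylsulfonyl on the ring

The compounds below may be only part of what the source reports. "The series", "measured", "known", "first", "only" and "open" are said of these compounds alone.

Measured so far:
- compound 1, `O=C(CCCCCCc1ccccc1)c1ncc(-c2cccs2)s1`: > 10000 nM
- compound 2, `Cn1nnc(C(=O)CCCCCCc2ccccc2)n1`: > 10000 nM
- compound 3, `CC(=O)c1coc(C(=O)CCCCCCc2ccccc2)n1`: 123 nM

In an assay on HEK-293T cells for inhibition of diacylglycerol lipase-alpha (Homo sapiens), read by colorimetric assay (on this read-out higher numbers stand for weaker inhibition and lower numbers for stronger inhibition), compound 1 returns only a limit, > 10000 nM. Compound 2 likewise returns a limit in this assay, > 10000 nM. Within the data shown here, compound 3 is the single compound with a number in this assay, 123 nM. Compound 3 thereby stands apart from compound 1 and compound 2, which sit at the limit of > 10000 nM in this assay, at which 2 of the 3 values shown sit.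

Compound 4, `CS(=O)(=O)c1coc(C(=O)CCCCCCc2ccccc2)n1`, has not yet been measured. It differs from compound 3 in one place: methylsulfonyl in place of acetyl on an aromatic carbon. Among the measured compounds shown here, no measured pair in the set shows this kind of exchange, so the step has to be judged from compound 3 alone. The expectation is a modest weakening, somewhat beyond the scatter, with the estimated step from compound 3 to compound 4 being a 2.8-fold higher number from compound 3 to compound 4 (0.45 log units; beyond the scatter). Compound 4 is therefore estimated at 350 nM, with a range from 70 nM to 2500 nM in this assay.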

Compound 4, half-maximal inhibitory concentration: 389 nM
Compound 4: the middle estimate sits 1.1-fold (0.05 log units) below what was measured, and the stated range covers the measured number.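

In this assay, the exchange on the aromatic carbon next to the ring nitrogen gives a 3.2-fold higher number from compound 3 to compound 4 (0.50 log units; beyond the scatter). Among these compounds, the acetyl of compound 3 is therefore not the only group at this place that returns a measured number, and methylsulfonyl, with its second hydrogen-bond acceptor and one more heavy atom, costs only a modest step. With this result, compound 4 joins compound 3 outside the assay limit: the limit of > 10000 nM in this assay, at which 2 of the 4 values shown sit.

A single exchange cannot show which feature of either group sets the size of this step, and the two compounds give no trend at this place. Among the compounds shown here, still open are a nitrile, a carboxylic acid or an amide on the same aromatic carbon, and a shorter or longer chain in place of the one shared by compound 3 and compound 4.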